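From 3-fluorobenzyl to 2-fluorobenzyl on compound 1

The source may hold more compounds than are shown below. What is called first, only, known or untested is meant among the compounds shown, and "the series" means these compounds.

compound 1 `CN(Cc1cccc(F)c1)C(=O)CCCNC(=O)c1ccc(S(C)(=O)=O)c([N+](=O)[O-])c1` | > 27000 nM
compound 2 `CS(=O)(=O)c1ccc(C(=O)NCC(=O)N(Cc2ccccc2)Cc2ccccc2)cc1[N+](=O)[O-]` | 11900 nM
compound 3 `CS(=O)(=O)c1ccc(C(=O)NCCC(=O)N2CCc3ccccc3C2)cc1[N+](=O)[O-]` | > 27000 nM

In an ADME assay on HepG2 cells (Homo sapiens) for cytotoxicity, read by CellTiter-Glo and ATP content, with a stated time of 72 h (a higher number here means that more compound is needed for the effect, a lower number that less compound is needed), compound 1 reports only a limit (> 27000 nM) and not a number. Compound 3 also reports only a limit (> 27000 nM). Compound 2 is the only one of the three with a true number (11900 nM). The position of compound 1 is thus the limit of > 27000 nM in this assay, at which 2 of the 3 values shown sit, and no exact figure exists for it.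

The next compound, compound 4 `CN(Cc1ccccc1F)C(=O)CCCNC(=O)c1ccc(S(C)(=O)=O)c([N+](=O)[O-])c1`, carries 2-fluorophenyl in place of 3-fluorophenyl on a saturated chain carbon bound to an amide-type nitrogen. For the measured compounds named here, no two measured compounds differ in one place, so the data offer no direct measure of such a change. The expectation therefore starts from the limit of compound 1 (> 27000 nM), and no shift beyond the usual scatter is foreseen. The expected step in this assay is small (a number no higher from compound 1 to compound 4 (the limit leaves the size open)). For compound 4 the estimated value is 27000 nM, with an expected range of (15000 nM to 40000 nM).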

Compound 4, half-maximal effective concentration: > 27000 nM
Compound 4 ended at the assay's limit (the forecaster's own chance of this, stated with the estimate: 75%); the middle value lies on the limit itself.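

In this assay, compound 1 and compound 4 each report only a limit and not a number, and the step between them cannot be read. The compounds shown leave open the exact value of either compound, and both stand at the same mark: the limit of > 27000 nM in this assay, at which 3 of the 4 values shown sit.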